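Buffer stability of a bis(trifluoromethyl)phenyl warhead series

A few compounds are considered here, and "the series" means these few. Any claim that something is new, unique, unknown or untested is made for them only; others in the source may bear on it.

Measured so far in an ADME assay for pharmacokinetics, read by HPLC, in phosphate buffer, with a stated time of 72 h, at pH 7.4, tested at 250 uM; on this read-out higher numbers stand for a longer-lived compound and lower numbers for a shorter-lived compound:
- compound 1, `C=CC(=O)Nc1cc(C(F)(F)F)cc(C(F)(F)F)c1`: 5.3 h
- compound 2, `C=CC(=O)Oc1cc(C(F)(F)F)cc(C(F)(F)F)c1`: < 0.017 h
- compound 3, `C=CS(=O)(=O)c1cc(C(F)(F)F)cc(C(F)(F)F)c1`: < 0.017 h

Compound 3 carries a vinylsulfonyl on the shared core. In this assay compound 3 gives only a limit, < 0.017 h, not a number. Compound 2 likewise gives only a limit in this assay, < 0.017 h. Both sit at the limit of < 0.017 h in this assay, at which 2 of the 3 values shown sit, so compound 3 stands at the floor of what the assay can report, and the step that the two limits leave unreadable from compound 2 to compound 3 cannot be sized. Against the amide, the step of an at least 310-fold lower number from compound 1 to compound 3 (2.49 log units; beyond the scatter) shows how far compound 3 lies below compound 1, the only compound with a readable half-life.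

The next compound, compound 4, `C=Cc1cc(C(F)(F)F)cc(C(F)(F)F)c1`, differs from compound 3 in one place: vinyl in place of vinylsulfonyl on an aromatic carbon. Going by the values given here, no measured step matches this change; the measured steps swap one group bearing a carbonyl or sulfonyl for another, and the vinylsulfonyl of compound 3 and the (vinylcarbonyl)oxy of compound 2 both fall to the limit, while only the (vinylcarbonyl)amino of compound 1 is readable. Removing the sulfonyl altogether is expected to lengthen the half-life well beyond the scatter, an at least 8800-fold higher number from compound 3 to compound 4 (3.94 log units; beyond the scatter), most likely past the window of this assay. The expected value for compound 4 is 150 h, between 30 h and 1000 h.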

Compound 4, half-life: > 50 h
Compound 4: a limit, no number (the forecaster's own chance of this, stated with the estimate: 70%); the middle value is on the limit's open side.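

In this assay, going by these compounds alone, compound 4 gives only a limit, > 50 h, and it is the sole compound at this upper limit: the limit of > 50 h in this assay, at which 1 of the 4 values shown sits. Until now this place on the aromatic carbon, meta to two trifluoromethyl groups, had shown a vinyl only as part of a larger group, and the vinyl carried directly there does not share the short half-lives seen with the sulfonyl and carbonyloxy linkages, with an at least 2900-fold higher number from compound 3 to compound 4 (3.46 log units; beyond the scatter) and an at least 2900-fold higher number from compound 2 to compound 4 (3.46 log units; beyond the scatter). The amide, the only readable half-life in the series, also no longer marks the long-lived end of it, with an at least 9.4-fold higher number from compound 1 to compound 4 (0.97 log units; beyond the scatter).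

With compound 2 and compound 3 at one limit and compound 4 at the other, the steps between limits give only a minimum size, and the step between compound 2 and compound 3 cannot be read at all. The compounds shown also leave open how a propionamide, a chloroacetamide or a vinyl ketone would fall on the shared core, and whether the order among these groups holds on a core without the two trifluoromethyl groups.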